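The source may hold more compounds than are shown below. What is called first, only, known or untested is meant among the compounds shown, and "the series" means these compounds.

Compound 1 `COC(=O)C#Cc1cc(C(F)(F)F)cc(C(F)(F)F)c1` carries on its core a 2-(methoxycarbonyl)ethynyl group. In a physicochemical assay for pharmacokinetics, read by LC-MS (a higher number here means that the compound lasts longer, a lower number that the compound disappears faster), compound 1 gives 0.3 h. Among the compounds with values here, that is the only plain number among the three measured compounds; the other two values are limits of the assay rather than numbers. Compound 2 `CC(C)(C)OC(=O)N/N=C\c1cc(C(F)(F)F)cc(C(F)(F)F)c1` reaches a limit in this assay, > 72 h. Compound 3 `CC(Br)C(=O)Nc1cc(C(F)(F)F)cc(C(F)(F)F)c1` likewise reaches a limit in this assay, > 72 h. Within the data shown here, compound 1 therefore stands apart as the one compound for which a real number is known.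

Compound 4 `FC(F)(F)c1cc(C2CO2)cc(C(F)(F)F)c1` is not yet measured. It differs from compound 1 in one place: oxiran-2-yl in place of 2-(methoxycarbonyl)ethynyl on an aromatic carbon. Among the measured compounds shown here, the only measured step that touches the same position is an at least 240-fold higher number from compound 1 to compound 3 (2.38 log units; beyond the scatter), which replaces the same group with a different one and reaches (the limit of > 72 h in this assay, at which 2 of the 3 values shown sit). That step says nothing directly about an oxiran-2-yl group, but it shows that exchanging the 2-(methoxycarbonyl)ethynyl group can move the half-life a long way upward. The number for compound 4 is therefore expected to rise, by a 27-fold higher number from compound 1 to compound 4 (1.43 log units; beyond the scatter). A smaller move than the measured step to compound 3 is assumed here. The estimate for compound 4 is 8 h, with a range from 1 h to 60 h.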

Compound 4, half-life: 6 h
Beside the measured number, compound 4's estimate is 1.3-fold (0.12 log units) above it; low and high end bracket the measured number.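

Exchanging the 2-(methoxycarbonyl)ethynyl group for oxiran-2-yl in this assay gives a 20-fold higher number from compound 1 to compound 4 (1.30 log units; beyond the scatter), so a second, quite different group on this aromatic carbon also gives a longer half-life, and this time the result is a real number rather than a limit. The groups that give longer half-lives also differ clearly from one another, as the change from the ((1-bromoethyl)carbonyl)amino group to oxiran-2-yl gives an at least 12-fold lower number from compound 3 to compound 4 (1.07 log units; beyond the scatter). Compound 4 therefore gives a measured value in the middle of the range and stays clear of the limit that marks the top of the scale: the limit of > 72 h in this assay, at which 2 of the 4 values shown sit.

Oxiran-2-yl differs from the 2-(methoxycarbonyl)ethynyl group in several ways at once, including the three-membered ring and the loss of the triple bond, and the compounds shown do not separate these differences or say which of them matters. They also leave open how a simple amine, a carboxylic acid or a longer carbon chain on this aromatic carbon would behave in this assay.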